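The compounds below may be only part of what the source reports. "The series", "measured", "known", "first", "only" and "open" are said of these compounds alone.

Working notes on the series in a functional assay on 786-0 cells (Homo sapiens) for inhibition, read by sulforhodamine B assay, with a stated time of 48 h; a higher number here means that more compound is tolerated, a lower number that less compound is tolerated. Compound 1 `COc1cc(-c2cc(/C=C/C(=O)c3ccc(N)cc3)[nH]n2)cc(OC)c1OC` gives 27600 nM. Compound 3 `COc1cc(C(=O)/C=C/c2cc(-c3cc(OC)c(OC)c(OC)c3)n[nH]2)cc(OC)c1OC` gives 6760 nM. For compound 2 `COc1cc(-c2cc(/C=C/C(=O)c3ccc(Cl)c(Cl)c3)[nH]n2)cc(OC)c1OC` only a limit of the assay is known, > 100000 nM, so it stands at the limit of > 100000 nM in this assay, at which 1 of the 3 values shown sits, and carries no number of its own. Within the data shown here, the one measured change at the carbonyl carbon is the step of an at least 3.6-fold higher number from compound 1 to compound 2 (0.55 log units; beyond the scatter), which moves the series from a number to the limit.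

Compound 4 `COc1cc(-c2cc(/C=C/C(=O)c3ccc(F)c(F)c3)[nH]n2)cc(OC)c1OC` has not yet been measured in this assay. It differs from compound 2 by 3,4-difluorophenyl in place of 3,4-dichlorophenyl on a carbonyl carbon. Among the measured compounds shown here, no measured step exchanges one halogen pattern for another on this carbonyl carbon, so the step of an at least 3.6-fold higher number from compound 1 to compound 2 (0.55 log units; beyond the scatter) is the only guide: it shows that a dihalogenated ring in this position reached the limit, while the aminophenyl of compound 1 gave a number. Compound 4 keeps a dihalogenated ring, so the step of an at least 1.1-fold lower number from compound 2 to compound 4 (0.07 log units; that floor lies within the scatter) is expected to be small and compound 4 is expected to stay close to the limit region, with no change beyond the scatter. The estimate for compound 4 is 85000 nM, with a range from 30000 nM to 200000 nM, and a fair chance that this assay again reports only a limit.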

Compound 4, concentration lethal to 50% of the cells: > 100000 nM
Compound 4: only a limit was reported; the forecaster's own chance of this, stated with the estimate: 45%; at least 1.1-fold (0.07 log units) between middle value and limit.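

In this assay compound 2 and compound 4 now both sit at a limit, so two different dihalogenated rings on this carbonyl carbon end at the same place: the limit of > 100000 nM in this assay, at which 2 of the 4 values shown sit. Exchanging 4-aminophenyl for 3,4-difluorophenyl gives an at least 3.6-fold higher number from compound 1 to compound 4 (0.55 log units; beyond the scatter), so the move away from the number of compound 1 no longer rests on the 3,4-dichlorophenyl of compound 2 alone. The step between compound 2 and compound 4 cannot be read, as both values are limits, and the exchange of chlorine for fluorine therefore has no size in these data.

Still open, as far as these compounds go, is whether a ring with a single halogen, such as a monofluorophenyl, or a ring with a carboxylic acid on this carbonyl carbon would return a number rather than a limit. Also open, from the compounds shown here alone, is whether the amine itself is what keeps compound 1 at 27600 nM, a question that an unsubstituted phenyl or a dimethylaminophenyl in the same place would address.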